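Amide aryl variation on the cyclopropane diamide

The compounds below may be only part of what the source reports. "The series", "measured", "known", "first", "only" and "open" are said of these compounds alone.

Within the data shown here, compound 3 `CN(C)C(=O)c1cc2cnc(Nc3ccc(NC(=O)C4(C(=O)Nc5ccc(Cl)c(C(F)(F)F)c5)CC4)cc3)nc2n1C1CCCC1` stands lowest of the three compounds measured so far: in a functional assay on T47D cells (Homo sapiens) for inhibition, read by CCK-8 assay, with a stated time of 72 h, tested at 1 uM (on this read-out lower numbers stand for less inhibition of growth and higher numbers for more inhibition of growth at the one concentration tested), compound 3 gives 6.9%. Its nearest neighbour is compound 2 `CN(C)C(=O)c1cc2cnc(Nc3ccc(NC(=O)C4(C(=O)Nc5ccc(Br)cc5)CC4)cc3)nc2n1C1CCCC1`, which in this assay gives 21.1%; the furthest is compound 1 `CN(C)C(=O)c1cc2cnc(Nc3ccc(NC(=O)C4(C(=O)Nc5ccccc5F)CC4)cc3)nc2n1C1CCCC1`, which in this assay gives 85.2%. Both steps that lead to compound 3 point downward, a number 78.3 percentage points lower from compound 1 to compound 3 (beyond the scatter) and a number 14.2 percentage points lower from compound 2 to compound 3 (beyond the scatter), and the same direction is seen in a number 64.1 percentage points lower from compound 1 to compound 2 (beyond the scatter).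

Compound 4 `CN(C)C(=O)c1cc2cnc(Nc3ccc(NC(=O)C4(C(=O)Nc5cccc(Cl)c5)CC4)cc3)nc2n1C1CCCC1` is not yet measured. It differs from compound 3 by 3-chlorophenyl in place of 4-chloro-3-(trifluoromethyl)phenyl on an amide-type nitrogen. Among the measured compounds shown here, no measured step matches this change exactly; the halogen sits at a position of the phenyl that has no precedent in the measured set. The closest guide is compound 2, whose 4-bromophenyl, like the 3-chlorophenyl of compound 4, carries a halogen alone, and which sits well below compound 1 as a number 64.1 percentage points lower from compound 1 to compound 2 (beyond the scatter) shows but still above compound 3. On that basis compound 4 is expected to lie nearer compound 2 than compound 3, with an expected step of a number 28.1 percentage points higher from compound 3 to compound 4 (beyond the scatter), upward and beyond the scatter, though with wide uncertainty. For compound 4 in this assay the estimate is 35%, with a range from 10% to 70%.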

Compound 4, percent growth inhibition at one concentration: 39.3%
Estimate against measurement, compound 4: 4.3 percentage points below; the range from low to high includes it.
By their numbers in this assay, from the lowest: compound 3; then compound 2; then compound 4; then compound 1.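

In this assay, 3-chlorophenyl in place of 4-chloro-3-(trifluoromethyl)phenyl on the amide-type nitrogen gives a number 32.4 percentage points higher from compound 3 to compound 4 (beyond the scatter), so a halogen-bearing aryl at this position does not by itself bring the number down to the low end of the series. Among aryls carrying one halogen the number also varies, with a number 18.2 percentage points higher from compound 2 to compound 4 (beyond the scatter) for 3-chlorophenyl in place of 4-bromophenyl, although that change alters both the halogen and its place on the ring. Even so, 3-chlorophenyl does not recover the level of 2-fluorophenyl, as a number 45.9 percentage points lower from compound 1 to compound 4 (beyond the scatter) shows, and compound 1 remains the highest of the four; no measurement offered here explains any of these differences.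

The compounds shown do not separate the identity of the halogen from its place on the phenyl, nor the loss of the trifluoromethyl group from that of the 4-chloro substituent. From the compounds shown here alone, it also remains open how a plain phenyl, or a phenyl carrying a methoxy group or an amine, would compare at this amide-type nitrogen.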